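This account rests on a few compounds, and the source may have more. Where it says the series, first, only, none or still open, it means among the compounds named here.

Compound 1 `COc1ccc2cc(C(C)c3nnc4n3N=C(c3ccc([N+](=O)[O-])cc3)CS4)ccc2c1` and compound 2 `COc1ccc(C2=Nn3c(nnc3C(C)c3ccc4cc(OC)ccc4c3)SC2)cc1` share one core and differ only in the group on the outer aromatic ring. In a functional assay on Huh-7 cells (Homo sapiens) for inhibition, read by sulforhodamine B assay, with a stated time of 72 h (on this read-out lower numbers stand for stronger inhibition and higher numbers for weaker inhibition), compound 1 gives 14700 nM, and in this assay compound 2 gives 8500 nM. The step of a 1.7-fold lower number from compound 1 to compound 2 (0.24 log units; within the scatter) stays inside the scatter of repeated measurements, so the two numbers cannot be told apart, and compound 2 cannot be called stronger than compound 1 on what has been measured.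

Compound 3 `COc1ccc2cc(C(C)c3nnc4n3N=C(c3ccc(Cl)cc3)CS4)ccc2c1` is the next member of the series. It differs from compound 2 by chloro in place of methoxy on an aromatic carbon. Among the compounds with values here, the only measured step that bears on this change is the swap of groups at the same position, a 1.7-fold lower number from compound 1 to compound 2 (0.24 log units; within the scatter), which was too small to count. A second swap at that position therefore gives no reason to expect a step beyond the scatter in this assay, in either direction. For compound 3 the expected value in this assay is 9000 nM, with a range from 3500 nM to 25000 nM. This estimate means a step of a 1.1-fold higher number from compound 2 to compound 3 (0.02 log units; within the scatter) that is expected to stay within the usual scatter.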

Compound 3, half-maximal inhibitory concentration: 5600 nM
Compound 3: the middle estimate sits 1.6-fold (0.21 log units) above what was measured; the range from low to high includes it.
By their numbers in this assay, from the lowest: compounds 3, 2 and 1 (each within the scatter of the next, the first and the last beyond it).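

In this assay, within the data shown here, the step of a 2.6-fold lower number from compound 1 to compound 3 (0.42 log units; beyond the scatter) is the first at this position to lie beyond the scatter, though it is a modest one, and it comes with chloro in place of nitro on an aromatic carbon. The step of a 1.5-fold lower number from compound 2 to compound 3 (0.18 log units; within the scatter) stays within the scatter, so compound 2 and compound 3 cannot be told apart. Compound 2 also cannot be told apart from compound 1, and the three groups do not fall into a clean order: only compound 3 and compound 1 are separated, with compound 3 the stronger of that pair. Nothing measured here explains this difference between chloro and nitro.

As far as these compounds go, whether an amine, a carboxylic acid or a longer chain such as ethoxy on this ring would move the number further, in either direction, remains open. Also open, from the compounds shown here alone, is whether the gain from nitro to chloro would hold on a different core, as all three compounds share one core and differ only in this group.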